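The compounds below may be only part of what the source reports. "The series", "measured", "known", "first", "only" and "open" are said of these compounds alone.

Working notes on the series. In an ADME assay for permeability, using PAMPA, with a stated time of 30 min, at pH 7.4 (on this read-out lower numbers stand for lower permeability and higher numbers for higher permeability), compound 3 `COc1cccc(CNCCCNc2ccnc3cc(CCc4ccccc4)ccc23)c1O` gives 23 10^-6 cm/s. For the measured compounds named here, compound 2 `COc1cccc(CNCCCNc2ccnc3cc(Cc4cccc(C(F)(F)F)c4)ccc23)c1O` gives 23 10^-6 cm/s in this assay, so compound 3 stands level with compound 2, the two being together the lowest of the three numbers measured so far, and the step of no change at the digits printed from compound 2 to compound 3 (within the scatter) lies within the scatter. Compound 1 `COc1cccc(CNCCCNc2ccnc3cc(-c4ccc(C(F)(F)F)cc4)ccc23)c1O` gives 237 10^-6 cm/s in this assay and is the furthest from compound 3, with a 10-fold lower number from compound 1 to compound 3 (1.01 log units; beyond the scatter); the corresponding step of a 10-fold lower number from compound 1 to compound 2 (1.01 log units; beyond the scatter) is of the same size.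

Compound 4 `COc1cccc(CNCCCNc2ccnc3cc(C4CCCCC4)ccc23)c1O` has not yet been measured. Its difference from compound 3 is cyclohexyl in place of phenethyl on an aromatic carbon. Going by the values given here, of the measured steps, the one running from compound 1 to compound 3 bears most closely, as it too replaces a group bound directly to the aromatic carbon by a chain-linked group: a 10-fold lower number from compound 1 to compound 3 (1.01 log units; beyond the scatter). The step of no change at the digits printed from compound 2 to compound 3 (within the scatter) shows that an exchange between two chain-linked groups left the number unchanged. Compound 4 returns to direct attachment, though with a non-aromatic ring, so the comparison with compound 1 is only partial and a step smaller than that one is expected, upward. For compound 4 the expected value in this assay is 60 10^-6 cm/s, with a range of 15 10^-6 cm/s to 240 10^-6 cm/s. The expected step is a 2.6-fold higher number from compound 3 to compound 4 (0.42 log units; beyond the scatter).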

Compound 4, apparent permeability in the ADME assay: 23 10^-6 cm/s
Compound 4: the middle estimate sits 2.6-fold (0.42 log units) above what was measured, and the stated range covers the measured number.
By their numbers in the ADME assay, from the lowest: compounds 2, 3 and 4 (each within the scatter of the next); then compound 1.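

In the ADME assay, cyclohexyl on the aromatic carbon falls in with the groups that reach the ring through a saturated chain (no change at the digits printed from compound 3 to compound 4 (within the scatter); no change at the digits printed from compound 2 to compound 4 (within the scatter)), so a ring bound directly to this position does not by itself restore the high number, and 4-(trifluoromethyl)phenyl alone stands apart among the groups shown (a 10-fold lower number from compound 1 to compound 4 (1.01 log units; beyond the scatter)). The exchange of phenethyl for cyclohexyl, with its change from a six-membered aromatic ring to a non-aromatic one and from 8 to 6 heavy atoms, also leaves the second read-out untouched: in a physicochemical assay for acid dissociation, compound 3 gives 9.47 and compound 4 gives 9.47 (no change at the digits printed from compound 3 to compound 4 (within the scatter)). No measurement at hand speaks to the reason for either result.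

Open, going by these compounds, is whether the high number of compound 1 goes with the directly bound aromatic ring, with its trifluoromethyl group, or with the two together, a question that an unsubstituted phenyl at this carbon would address. The compounds shown also leave open how the number responds when this position carries a group containing atoms other than carbon and fluorine, such as an amine or a carboxylic acid.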